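The compounds below may be only part of what the source reports. "The series", "measured", "known", "first", "only" and "open" are said of these compounds alone.

Compound 1, `Cn1cc(-c2cnc3ccnc(N)c3c2)cn1`, in a functional assay on A549 cells (Homo sapiens) for antiproliferative activity, read by MTT assay, with a stated time of 48 h (a lower number here means a stronger inhibitor, a higher number a weaker inhibitor), gives 33400 nM.
Compound 2, `CC(=O)Nc1nccc2ncc(-c3cnn(C)c3)cc12`, in this assay gives > 50000 nM, which is a limit of the assay.
Compound 3, `COc1ccc(C(=O)Nc2nccc3ncc(-c4cnn(C)c4)cc23)cc1`, in this assay gives > 50000 nM, again a limit of the assay and not a number.

Compound 3 therefore stands at the upper edge of what this assay can report, and it shares that position with one other compound: the limit of > 50000 nM in this assay, at which 2 of the 3 values shown sit. Compound 4, `Cn1cc(-c2cnc3ccnc(NC(=O)c4cccnc4)c3c2)cn1`, is the next compound in this series and differs from compound 3 only in the acyl group on the amide-type nitrogen: pyridin-3-yl in place of 4-methoxyphenyl on a carbonyl carbon.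

For the measured compounds named here, two measured steps touch the same region of the molecule. The first, an at least 1.4-fold higher number from compound 1 to compound 2 (0.17 log units; that floor lies within the scatter), is small and its floor lies within the scatter. The second, a step that the two limits leave unreadable from compound 2 to compound 3, is trapped between two limits and its size cannot be read. Neither step gives a direction or a size from which a move away from the limit could be predicted, so the expectation for compound 4 is that it remains at or near the limit in this assay.

The estimate for compound 4 is 50000 nM, with a range from 20000 nM to 200000 nM. Relative to compound 3 this expected step is a number no higher from compound 3 to compound 4 (the limit leaves the size open).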

Compound 4, half-maximal inhibitory concentration: > 50000 nM
Compound 4 ended at the assay's limit; the forecaster's own chance of this, stated with the estimate: 65%; the middle value sits exactly at the limit.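

In this assay compound 4 gives > 50000 nM, which is a limit of the assay and not a number. The steps among compound 2, compound 3 and compound 4 cannot be read, but the result does add one fact: pyridin-3-yl, a six-membered aromatic ring with a hetero atom, on the carbonyl carbon leaves the compound at the same limit as methyl and 4-methoxyphenyl: the limit of > 50000 nM in this assay, at which 3 of the 4 values shown sit. For the compounds shown here, the one step that can be read is an at least 1.4-fold higher number from compound 1 to compound 4 (0.17 log units; that floor lies within the scatter), and it gives only a floor, so the true size of the change from the free amine stays hidden.

Going by these compounds, it remains open whether any group on this carbonyl carbon would bring a value back under the limit, such as a longer alkyl chain, or a ring carrying a carboxylic acid or an aminomethyl group. It is also open whether a sulfonyl group or a urea on that nitrogen, in place of the acyl groups shown, would give a readable number.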